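This account rests on a few compounds, and the source may have more. Where it says the series, first, only, none or still open, it means among the compounds named here.

Measured compounds:
- compound 1, `N=C(N)NCCC[C@H](NC(=O)CN(c1ncnc2c1ncn2C1CCCCO1)C1CC1)C(=O)OCc1ccccc1`, gives 34.3% in a functional assay on the whole organism (Tail, strain ICR) with Mus musculus as the target, in the tail flick test, with a stated time of 30 min, at a dose of 25 umol/kg by the oral route; on this read-out higher numbers stand for a stronger effect at the one dose given and lower numbers for a weaker effect
- compound 2, `N=C(N)NCCC[C@H](NC(=O)CN(c1nc(Cl)nc2[nH]cnc12)C1CC1)C(=O)O`, gives 45.4% in this assay

Of these two numbers, compound 1 stands lowest, and compound 2 lies higher by a margin that exceeds the usual scatter of this assay. Compound 3, `O=C(CN(c1ncnc2c1ncn2C1CCCCO1)C1CC1)N[C@@H](CC(=O)OCc1ccccc1)C(=O)OCc1ccccc1`, has not yet been tested. It is reached from compound 1 by one change: a group of 10 heavy atoms (8 carbon, 2 oxygen; one six-membered aromatic ring of carbon only) in place of a group of 6 heavy atoms (3 carbon, 3 nitrogen; no ring), on a saturated chain carbon, two bonds along the chain from an amide-type nitrogen and a carbonyl carbon. The chain that leaves carries three nitrogen atoms and three hydrogen-bond donors, while the benzyloxycarbonyl group that enters brings a six-membered aromatic ring of carbon only and no donors. Going by the values given here, no pair of measured compounds differs in exactly this way, so nothing measured here shows how this exchange acts on the read-out. With no such guide, a drop rather than a rise seems the more likely outcome, though a result within the scatter cannot be ruled out. The expected step of a number 14.3 percentage points lower from compound 1 to compound 3 (beyond the scatter) is therefore downward. For compound 3 the estimated value in this assay is 20%, with a range from 5% to 40%.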

Compound 3, a percentage reported as activity, at one dose (the size of the read-out at that dose, not a potency): 31.8%
The estimate for compound 3 lay 11.8 percentage points below the measured number; the measured number falls inside the stated range.
By their numbers in this assay, from the lowest: compounds 3 and 1 (each within the scatter of the next); then compound 2.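

In this assay, putting benzyloxycarbonyl in place of the group of 6 heavy atoms on the saturated chain carbon gives a number 2.5 percentage points lower from compound 1 to compound 3 (within the scatter). Going by these compounds alone, this is the first comparison of two compounds that differ in only one place, and it shows that, at the one dose given, a group with 3 hydrogen-bond donors and no ring can be exchanged for one with 0 hydrogen-bond donors and a six-membered aromatic ring of carbon only, with no difference beyond the scatter. Nothing available here explains why the read-out stays within the scatter after so large an exchange.

The compounds shown leave open what a primary amine, a carboxylic acid or a simple methyl group would give on this same saturated chain carbon, and so how far the tolerance seen for these two groups extends. They also leave open whether the same exchange would act in the same way on a different core, since this single step rests on one pair of compounds at one dose.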